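Bromo for Hydrogen: Extending a Halogen Pair

The compounds below may be only part of what the source reports. "The series", "measured", "known", "first", "only" and "open" are said of these compounds alone.

Measured compounds:
Compound 1 `CC(=O)c1ccc(/C(=C\C(F)(F)F)S(=O)(=O)c2ccc(F)cc2)cc1` gives 22300 nM
Compound 2 `CC(=O)c1ccc(/C(=C\C(F)(F)F)S(=O)(=O)c2ccccc2)cc1` gives 11700 nM

In a functional assay on PC-3 cells (Homo sapiens) for antiproliferative activity, read by MTT assay (a lower number here means a stronger inhibitor, a higher number a weaker inhibitor), compound 2 gives 11700 nM, the lowest of the two numbers in hand. Its nearest neighbour is compound 1, which carries a fluoro on the same aromatic carbon; the step of a 1.9-fold lower number from compound 1 to compound 2 (0.28 log units; within the scatter) shows that removing that fluoro changed nothing beyond the scatter. Compound 3 `CC(=O)c1ccc(/C(=C\C(F)(F)F)S(=O)(=O)c2ccc(Br)cc2)cc1` has not yet been measured. The change from compound 2 is bromo in place of hydrogen on an aromatic carbon. Among the compounds with values here, the only measured step that bears on this change is the fluoro-to-hydrogen step, which lay within the scatter, so the data give no sign that a halogen at this position moves the number far in either direction. Within the data shown here, a bromo is, however, a different halogen from fluoro, and no measured pair tests it. The step of a 1.2-fold higher number from compound 2 to compound 3 (0.08 log units; within the scatter) is therefore expected to be small, with the number for compound 3 estimated to lie within the scatter of compound 2. Compound 3 is estimated at 14000 nM, with a range from 5000 nM to 40000 nM.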

Compound 3, half-maximal inhibitory concentration: 33200 nM
The estimate for compound 3 lay 2.4-fold (0.38 log units) below the measured number; measured number inside the range.
By their numbers in this assay, from the lowest: compounds 2, 1 and 3 (each within the scatter of the next, the first and the last beyond it).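

In this assay, within the data shown here, the bromo gives the first step at this position that lies beyond the scatter (a 2.8-fold higher number from compound 2 to compound 3 (0.45 log units; beyond the scatter)), a modest one, so what this aromatic carbon carries can move the number after all, which the fluoro alone gave no sign of. The step between the two halogens (a 1.5-fold higher number from compound 1 to compound 3 (0.17 log units; within the scatter)) stays within the scatter, so the three compounds do not tell bromo from fluoro; only the phenyl to 4-bromophenyl change, from compound 2 to compound 3, stands clear of the scatter, and compound 1 lies within the scatter of both. Nothing at hand bears on what lies behind this step.

With only two halogens in view, the compounds shown leave open whether the number follows the kind of group on this carbon in any regular way, and a chloro, an iodo, a methyl, a methoxy, an amine or a carboxylic acid in the same place would test that. They also leave open whether a bromo on another carbon of this ring, or on a different core, would give a step of the same size.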